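Notes on the benzyl change from compound 1 to compound 4

A few compounds are considered here, and "the series" means these few. Any claim that something is new, unique, unknown or untested is made for them only; others in the source may bear on it.

Measured in an assay on Sf21 cells for inhibition of ubiquitin carboxyl-terminal hydrolase 7 (Homo sapiens), read by spectrophotometry, with stated times of 30 min and 2 h; on this read-out higher numbers stand for weaker inhibition and lower numbers for stronger inhibition:
compound 1 `O=c1c2cnn(-c3ccc(F)cc3)c2ncn1CC1(O)CCN(Cc2ccc(Cl)cc2)CC1`: 8000 nM
compound 2 `Cc1ccccc1CN1CCC(O)(Cn2cnc3c(cnn3-c3ccc(F)cc3)c2=O)CC1`: "not determined" (no result reported)
compound 3 `O=c1c2cnn(-c3ccc(F)cc3)c2ncn1CC1(O)CCN(Cc2ccc(Cl)cc2Cl)CC1`: 3300 nM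

Compound 1 stands highest of the two numbers reported; its nearest neighbour is compound 3, and the step of a 2.4-fold lower number from compound 1 to compound 3 (0.38 log units; beyond the scatter) came from a chloro in place of hydrogen on an aromatic carbon. Compound 2 carries no reported result.

Compound 4 `COC(=O)c1ccc(CN2CCC(O)(Cn3cnc4c(cnn4-c4ccc(F)cc4)c3=O)CC2)c(Br)c1` differs from compound 1 by 2-bromo-4-(methoxycarbonyl)phenyl in place of 4-chlorophenyl on a saturated chain carbon bound to an amine nitrogen in a ring. Going by the values given here, only one measured step bears on this: a 2.4-fold lower number from compound 1 to compound 3 (0.38 log units; beyond the scatter), where a second halogen entered the benzyl ring. Among the compounds with values here, in compound 4 the chlorine leaves altogether while a bromine and a methoxycarbonyl enter, an exchange no measured step covers, so the direction is uncertain. Compound 4 is expected to show a modest lowering in this assay, a 1.6-fold lower number from compound 1 to compound 4 (0.20 log units; within the scatter), and is estimated at 5000 nM within 1500 nM to 16000 nM.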

Compound 4, half-maximal inhibitory concentration: 900 nM
For compound 4 the middle estimate is 5.6-fold (0.74 log units) above the measured one; measured number outside the range, below it.
By their numbers in this assay, from the lowest: compound 4; then compound 3; then compound 1.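

In this assay, going by these compounds alone, this position on the benzyl ring accepts more than halogen alone: 2-bromo-4-(methoxycarbonyl)phenyl in place of 4-chlorophenyl gives an 8.9-fold lower number from compound 1 to compound 4 (0.95 log units; beyond the scatter) and the largest step so far. The same group also improves on 2,4-dichlorophenyl, with a 3.7-fold lower number from compound 3 to compound 4 (0.56 log units; beyond the scatter) and compound 4 holding the lowest number of the three measured compounds. No supporting measurement accounts for this gain.

The bromine and the methoxycarbonyl arrive together, leaving their separate contributions unresolved. On these data alone, whether a carboxylic acid or a primary amide in place of the methyl ester would hold the number also remains open.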